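Removing the Methoxy Group: Permeability Expected to Recover

The compounds below may be only part of what the source reports. "The series", "measured", "known", "first", "only" and "open" are said of these compounds alone.

This account follows a series of sulfonamide-amide compounds sharing one core, measured in an ADME assay on MDCK-II cells (Canis lupus familiaris) for permeability; on this read-out lower numbers stand for lower permeability and higher numbers for higher permeability. Compound 1 `Cc1noc(CNC(=O)c2ccc(C)c(S(=O)(=O)Nc3ccc(Cl)cc3)c2)n1` gives 19 10^-6 cm/s, and compound 2 `Cc1ccc(NS(=O)(=O)c2cc(C(=O)NCc3nc(C)no3)ccc2C)cc1` gives 20 10^-6 cm/s; the step of a 1.1-fold higher number from compound 1 to compound 2 (0.02 log units; within the scatter) is within the scatter. Among the compounds with values here, compound 3 `COc1ccc(C(=O)NCc2nc(C)no2)cc1S(=O)(=O)Nc1ccc(C)cc1` gives 8 10^-6 cm/s, which is the lowest of the three numbers, and the step of a 2.5-fold lower number from compound 2 to compound 3 (0.40 log units; beyond the scatter) is the one change beyond the scatter in this set.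

Compound 4 `Cc1ccc(NS(=O)(=O)c2cccc(C(=O)NCc3nc(C)no3)c2)cc1` has not yet been measured in this assay. The change from compound 3 to compound 4 is hydrogen in place of methoxy on an aromatic carbon. Within the data shown here, the most relevant measured step is the one from compound 2 to compound 3, where methoxy in place of methyl on an aromatic carbon produced a modest drop; compound 4 now carries neither group at that position. Because compound 2 with a methyl there gives 20 10^-6 cm/s, and because the methoxy of compound 3 coincided with a 2.5-fold lower number from compound 2 to compound 3 (0.40 log units; beyond the scatter), a modest recovery is expected. Compound 4 is therefore estimated at 17 10^-6 cm/s, with a range from 8 10^-6 cm/s to 35 10^-6 cm/s. The expected step is a 2.1-fold higher number from compound 3 to compound 4 (0.33 log units; beyond the scatter).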

Compound 4, apparent permeability: 22 10^-6 cm/s
Estimate against measurement, compound 4: 1.3-fold (0.11 log units) below, within the range that was stated.
By their numbers in this assay, from the lowest: compound 3; then compounds 1, 2 and 4 (each within the scatter of the next).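

In this assay, taking the methoxy off this aromatic carbon gives a 2.8-fold higher number from compound 3 to compound 4 (0.44 log units; beyond the scatter), so the low number of compound 3 goes with the methoxy and not with the shared core. The earlier compounds shown here, all with methyl or methoxy here, could not show how hydrogen compares, and a 1.1-fold higher number from compound 2 to compound 4 (0.04 log units; within the scatter) now places hydrogen and methyl level at this position. Nothing at hand explains why the methoxy goes with the lower number.

As far as these compounds go, whether the drop belongs to methoxy alone stays open: ethoxy, hydroxyl or an amine on this carbon could fall with it or stay level with hydrogen and methyl. Also open, from the compounds shown here alone, is whether chloro in place of methyl, a change within the scatter with methyl at this position, would remain so with hydrogen there.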